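Amide-to-ether change on the selenocyanate side chain

A few compounds are considered here, and "the series" means these few. Any claim that something is new, unique, unknown or untested is made for them only; others in the source may bear on it.

Compound 1 `COc1ccc(N(C)c2nc(C)nc3ccccc23)cc1C(=O)NCC[Se]C#N` is the weaker of the two measured entries: in a functional assay on RKO cells (Homo sapiens) for inhibition, read by MTT assay, with a stated time of 48 h (on this read-out lower numbers stand for stronger inhibition and higher numbers for weaker inhibition), compound 1 gives 1170 nM, while compound 2 `C[Se]c1ccc(N(C)c2nc(C3CC3)nc3ccccc23)cc1` gives 21 nM, a gap beyond the scatter. Compound 3 `COc1ccc(N(C)c2nc(C)nc3ccccc23)cc1OCC[Se]C#N` differs from compound 1 by a group of 6 heavy atoms (3 carbon, 1 nitrogen, 1 oxygen, 1 selenium; no ring) in place of a group of 8 heavy atoms (4 carbon, 2 nitrogen, 1 oxygen, 1 selenium; no ring), on an aromatic carbon. Among the measured compounds shown here, no measured pair shows this change, so its size is unknown. The expectation is a step of a 1.5-fold lower number from compound 1 to compound 3 (0.17 log units; within the scatter), a modest move toward a lower number, within or just past the scatter. Compound 3 is estimated at 800 nM, with a range of 250 nM to 3000 nM.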

Compound 3, half-maximal inhibitory concentration: 27 nM
Estimate against measurement, compound 3: 30-fold (1.47 log units) above; the whole stated range lies above it.
By their numbers in this assay, from the lowest: compounds 2 and 3 (each within the scatter of the next); then compound 1.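

In this assay the amide-to-ether change on the selenocyanate side chain gives a 43-fold lower number from compound 1 to compound 3 (1.64 log units; beyond the scatter) on an aromatic carbon ortho to a methoxy group, so this position is sensitive to the side chain it carries. The group that leaves has a hydrogen-bond donor and a double bond, the group that enters has neither, and this single pair cannot separate those differences from the shorter chain. No data here account for the size of the step.

Open, as far as these compounds go, is whether the ether oxygen itself matters, which a plain carbon chain or a longer ether chain would address. Also open, from the compounds shown here alone, is how an amine or a carboxylic acid at the chain end would compare with the selenocyanate.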